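Difluorophenyl for Ethylphenyl on a Fatty Acid Receptor Agonist

The compounds below may be only part of what the source reports. "The series", "measured", "known", "first", "only" and "open" are said of these compounds alone.

Compound 1 `CC#CC(CC(=O)O)c1ccc(OCc2ccn3cc(-c4ccc(CC)cc4)nc3c2)cc1` shows the highest number of the three measured compounds in an assay on isolated protein for agonist activity at Free fatty acid receptor 1 (Homo sapiens) (on this read-out higher numbers stand for an effect only at larger amounts of compound and lower numbers for an effect already at smaller amounts), giving 671 nM. Compound 2 `CC#CC(CC(=O)O)c1ccc(OCc2ccc3nc(-c4ccc(F)cc4)cn3c2)cc1` gives 623 nM and compound 3 `CC#CC(CC(=O)O)c1ccc(OCc2ccc3nc(-c4ccc(C)cc4C)cn3c2)cc1` gives 316 nM; the gap from compound 1 to compound 2 lies within the scatter, that to compound 3 beyond it. Compound 4 `CC#CC(CC(=O)O)c1ccc(OCc2ccn3cc(-c4ccc(F)cc4F)nc3c2)cc1` differs from compound 1 in one place: 2,4-difluorophenyl in place of 4-ethylphenyl on an aromatic carbon. For the measured compounds named here, the only measured step, a 2.0-fold lower number from compound 2 to compound 3 (0.29 log units; within the scatter), exchanges one aryl group and stays within the scatter, while compound 1 and compound 2, which differ in the aryl group and in the shared core, also show values within the scatter of each other. No step beyond the scatter is therefore expected, a 1.0-fold higher number from compound 1 to compound 4 (0.02 log units; within the scatter). Compound 4 is estimated at 700 nM, with a range from 250 nM to 2000 nM.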

Compound 4, half-maximal effective concentration: 792 nM
Estimate against measurement, compound 4: 1.1-fold (0.05 log units) below; the range from low to high includes it.
By their numbers in this assay, from the lowest: compounds 3, 2, 1 and 4 (each within the scatter of the next, the first and the last beyond it).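

In this assay, 2,4-difluorophenyl in place of 4-ethylphenyl on this aromatic carbon gives a 1.2-fold higher number from compound 1 to compound 4 (0.07 log units; within the scatter), the first one-place step read on the core of compound 1. On this core, the read-out does not separate the two aryl groups, although their substituents differ in kind and the count of heavy atoms stays the same. No measurement here explains this result.

Still open, as far as these compounds go, is whether an amine or a carboxylic acid at this position would keep the read-out in this range. So is whether 2,4-dimethylphenyl would read on this core as it does in compound 3.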